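This account rests on a few compounds, and the source may have more. Where it says the series, first, only, none or still open, it means among the compounds named here.

Measured compounds:
Compound 1, `Fc1ccc2nc(-c3cc(-c4ccccc4)nn3-c3ccccc3)ccc2c1`, in an ADME assay on Huh-7 cells (Homo sapiens) for cytotoxicity, read by XTT assay, with a stated time of 3 days, tested at 20 uM; a higher number here means a weaker effect of the compound at the concentration tested, a lower number a stronger effect: 126%
Compound 2, `Fc1ccc(-n2nc(-c3ccccc3)cc2-c2ccc3cc(F)ccc3n2)cc1`: 97.8%
Compound 3, `NS(=O)(=O)c1ccc(-n2nc(-c3ccccc3)cc2-c2ccc3cc(F)ccc3n2)cc1`: 89.2%

All three share one core and were read in this assay. Compound 2 differs from compound 1 by fluoro in place of hydrogen on an aromatic carbon, and this gave a number 28.2 percentage points lower from compound 1 to compound 2 (beyond the scatter). Compound 3 differs from compound 1 by sulfamoyl in place of hydrogen on an aromatic carbon, with a number 36.8 percentage points lower from compound 1 to compound 3 (beyond the scatter). Between compound 2 and compound 3 the step is a number 8.6 percentage points lower from compound 2 to compound 3 (within the scatter), so no order between these two is claimed, though compound 3 carries the lowest number of the three.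

Among the measured compounds shown here, compound 4, `NS(=O)(=O)c1ccc(-n2nc(-c3ccc(F)cc3)cc2-c2ccc3cc(F)ccc3n2)cc1`, has not yet been read in this assay. It differs from compound 3 by fluoro in place of hydrogen on an aromatic carbon, the same change as that from compound 1 to compound 2, made here on a core that bears sulfamoyl where compound 1 bears hydrogen. Because a number 28.2 percentage points lower from compound 1 to compound 2 (beyond the scatter) was beyond the scatter, compound 4 is expected to move lower than compound 3, but by a smaller step, estimated as a number 14.2 percentage points lower from compound 3 to compound 4 (beyond the scatter), since compound 3 already sits at 89.2% and the step from compound 2 to compound 3 was small. Compound 4 is therefore estimated at 75%, between 55% and 95%.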

Compound 4, a percentage reported as activity, at one concentration (the size of the read-out at that concentration, not a potency): 91.1%
The estimate for compound 4 lay 16.1 percentage points below the measured number, and the stated range covers the measured number.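

In this assay, fluoro in place of hydrogen gave a number 1.9 percentage points higher from compound 3 to compound 4 (within the scatter), so the clear step seen earlier on the core without sulfamoyl did not carry over to the core bearing it: the same change on two cores in this assay, a number 28.2 percentage points lower (beyond the scatter) from compound 1 to compound 2 and a number 1.9 percentage points higher (within the scatter) from compound 3 to compound 4, 30.1 percentage points apart, beyond the scatter of two such steps This shows that, in this series, the size of the step measured on one core cannot simply be transferred to another, although it rests on only these two steps and cannot say how general the difference is. It also does not show what causes the difference, and the sulfamoyl group cannot be singled out, since the fluoro stands on different phenyl rings in compound 2 and compound 4.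

The compounds shown leave open whether fluoro on the same phenyl ring of both cores would give matching steps. They also leave open how chloro or methoxy in place of that fluoro, or a carboxylic acid or an amine in place of sulfamoyl, would read in this assay.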